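The source may report more compounds than this note shows. Statements on the series, on what has been measured and on what is new or still open speak of the compounds shown alone.

Working notes on the series. Compound 1 `ClCc1ccc(Cn2cnc3nc(Cl)nc(Cl)c32)cc1` carries two chloro groups on the shared core; in a functional assay on BT-549 cells (Homo sapiens) for cytotoxicity, read by sulforhodamine B assay, with a stated time of 48 h (on this read-out higher numbers stand for lower toxicity in this test and lower numbers for higher toxicity in this test), compound 1 gives 6450 nM, the lowest of the two numbers recorded so far. Compound 2 `Nc1nc(Cl)c2ncn(Cc3cccc(CCl)c3)c2n1` differs from compound 1 in more than one place, and in this assay compound 2 gives 58900 nM; the two values lie beyond the scatter of each other, with compound 1 the lower. Among the measured compounds shown here, no pair of measured compounds differs in a single place, so no single-step change has yet been measured in this assay. Compound 3 `ClCc1ccc(Cn2cnc3ncnc(Cl)c32)cc1` is the next compound for this assay. Relative to compound 1 the change is hydrogen in place of chloro on an aromatic carbon. For the measured compounds named here, with no measured step to lean on, the expected step from compound 1 to compound 3 is a 2.3-fold higher number from compound 1 to compound 3 (0.37 log units; beyond the scatter), a modest move toward a higher number. Compound 3 is therefore estimated at 15000 nM, with a range from 5000 nM to 45000 nM.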

Compound 3, concentration lethal to 50% of the cells: 56200 nM
Compound 3: the middle estimate sits 3.7-fold (0.57 log units) below what was measured; the whole stated range lies below it.
By their numbers in this assay, from the lowest: compound 1; then compounds 3 and 2 (each within the scatter of the next).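

Among the compounds shown here, this gives the first single-place step: in this assay, hydrogen in place of chloro on the aromatic carbon between two ring nitrogen atoms gives an 8.7-fold higher number from compound 1 to compound 3 (0.94 log units; beyond the scatter). The step lies beyond the scatter, so the read-out is sensitive to this change at this position when the rest of compound 1 is held constant. No measurement at hand accounts for the size of this step.

On these data alone, whether the step would keep its size with a different group elsewhere on the molecule remains open, as a single pair cannot show this. Also open, as far as these compounds go, is how a bromo or a methoxy group on this same aromatic carbon would compare with chloro and hydrogen on an otherwise unchanged compound 1.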